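From Fluoro to Phenyl: Expecting Little Change in Acidity

The compounds below may be only part of what the source reports. "The series", "measured", "known", "first", "only" and "open" are said of these compounds alone.

Among the compounds with values here, compound 1, `N#C/C(=N\O)C(=O)Nc1ccc(F)cc1`, is one of two compounds measured in a physicochemical assay for acid dissociation, using potentiometric titration. In this assay compound 1 gives 5.01, the highest of the two numbers. Compound 2, `N#C/C(=N\O)C(=O)Nc1cccc(F)c1`, gives 4.92 in this assay; the two values lie within the scatter of each other, so no order between compound 1 and compound 2 can be read from them. Compound 3, `N#C/C(=N\O)C(=O)Nc1ccc(-c2ccccc2)cc1`, has not yet been measured. It differs from compound 1 in one place: phenyl in place of fluoro on an aromatic carbon. Within the data shown here, no measured pair shows what this kind of change does in this assay, and the only comparison available, between compound 1 and compound 2, stays within the scatter. The expected step is therefore small, estimated at a number 0.09 log units higher from compound 1 to compound 3 (within the scatter), which lies within the scatter and so points in no clear direction. For compound 3 the estimate is 5.1, within 4.7 to 5.5.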

Compound 3, acid dissociation constant: 5.03
The estimate for compound 3 lay 0.07 log units above the measured number, within the range that was stated.
By their numbers in this assay, from the lowest: compounds 2, 1 and 3 (each within the scatter of the next).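

In this assay, within the data shown here, putting phenyl in place of fluoro on this aromatic carbon comes with a number 0.02 log units higher from compound 1 to compound 3 (within the scatter), and this is the first measured pair for this kind of change. A single fluorine and a phenyl of 6 heavy atoms with its own ring can therefore occupy this place with no readable difference in the acid dissociation constant. Nothing available explains why the two numbers agree.

Going by these compounds, whether an amine or a carboxylic acid at this same place would also stay within the scatter of compound 1 remains open. The same question stands for a longer chain, and this single pair cannot show whether the agreement would hold for phenyl on another carbon of that ring.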